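Replacing 3-nitrophenyl with methoxymethyl on a carbonyl carbon

The compounds below may be only part of what the source reports. "The series", "measured", "known", "first", "only" and "open" are said of these compounds alone.

Compound 1 `COc1ccc(N2CCN(C)CC2)cc1Nc1ncc(F)c(Nc2ccc(F)cc2)n1` gives 910 nM
Compound 2 `O=C(Nc1cccc(Nc2ncc(F)c(Nc3ccc(F)cc3)n2)c1)c1cccc([N+](=O)[O-])c1` gives 12600 nM

In a functional assay on DU-145 cells (Homo sapiens) for antiproliferative activity, read by sulforhodamine B assay, with a stated time of 3 days (on this read-out lower numbers stand for stronger inhibition of growth and higher numbers for weaker inhibition of growth), compound 2 gives 12600 nM as the higher of the two values. Compound 3 `COCC(=O)Nc1cccc(Nc2ncc(F)c(Nc3ccc(F)cc3)n2)c1` has methoxymethyl in place of 3-nitrophenyl on a carbonyl carbon and has not yet been measured. Among the compounds with values here, no measured step covers this change, so the expectation rests only on compound 1 lying lower at 910 nM in this comparison. The expected change is a 3.6-fold lower number from compound 2 to compound 3 (0.56 log units; beyond the scatter) and would mean stronger inhibition of growth, modestly beyond the scatter. For compound 3 the estimated value is 3500 nM with an expected range from 1000 nM to 12000 nM.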

Compound 3, concentration for 50% growth inhibition: 4460 nM
Estimate against measurement, compound 3: 1.3-fold (0.11 log units) below; the range from low to high includes it.
By their numbers in this assay, from the lowest: compound 1; then compound 3; then compound 2.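

In this assay, methoxymethyl in place of 3-nitrophenyl on a carbonyl carbon gives a 2.8-fold lower number from compound 2 to compound 3 (0.45 log units; beyond the scatter). In this pair, the aromatic ring on the carbonyl carbon is therefore not needed for growth inhibition, and a much smaller group with no ring does modestly better. No measurement here accounts for the step. The compounds shown leave open whether an amine or a longer ether chain on the same carbonyl carbon would lower the number further. They also leave open how a plain phenyl would compare with 3-nitrophenyl.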